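Side chain on the aromatic nitrogen: notes on the series

A few compounds are considered here, and "the series" means these few. Any claim that something is new, unique, unknown or untested is made for them only; others in the source may bear on it.

Measured in a functional assay on PC-3 cells (Homo sapiens) for cytotoxicity, read by colorimetric assay and MTT assay; a higher number here means a weaker inhibitor, a lower number a stronger inhibitor:
- compound 1 `CCOC(=O)Cn1c(=O)c(-c2ccc(OC)cc2)cc2c(OC)cc(OC)cc21` gives 10000 nM
- compound 2 `COc1ccc(-c2cc3c(OC)cc(OC)cc3n(CCCC#N)c2=O)cc1` gives 10000 nM
- compound 3 `COc1ccc(-c2cc3c(OC)cc(OC)cc3n(CCC#N)c2=O)cc1` gives 10000 nM

Compound 3 at 10000 nM stands level with compounds 1 and 2 on these numbers. Compound 4 `CCN(CC)C(=O)CCn1c(=O)c(-c2ccc(OC)cc2)cc2c(OC)cc(OC)cc21` carries diethylcarbamoyl in place of cyano on a saturated chain carbon, two bonds along the chain from an aromatic nitrogen. The side-chain steps bearing on this are no change at the digits printed from compound 1 to compound 2 (within the scatter) together with no change at the digits printed from compound 1 to compound 3 (within the scatter) and no change at the digits printed from compound 2 to compound 3 (within the scatter) with none beyond the scatter. Within the data shown here, no measured compound carries diethylcarbamoyl, so this precedent is only indirect. The expected outcome is no change at the digits printed from compound 3 to compound 4 (within the scatter) in this assay with no step beyond the scatter expected. Compound 4 is estimated at 10000 nM within an expected range of 4000 nM to 15000 nM overall.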

Compound 4, half-maximal inhibitory concentration: 10000 nM
The estimate for compound 4 equals the measured number at the digits printed, and the stated range covers the measured number.
By their numbers in this assay, from the lowest: compounds 1, 2, 3 and 4 (each within the scatter of the next).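

In this assay, diethylcarbamoyl on a saturated chain carbon, with 7 heavy atoms against 2 for cyano, gives no change at the digits printed from compound 3 to compound 4 (within the scatter) in this series, and the comparisons with the other side chains read no change at the digits printed from compound 2 to compound 4 (within the scatter) and no change at the digits printed from compound 1 to compound 4 (within the scatter) on the same scale. The side chains ending in nitrile, ethyl ester and diethylcarbamoyl therefore all read alike here. Nothing available explains this result.

On these data alone, whether a primary amine or a carboxylic acid at the chain end would move the value remains open. A side chain that shifts the reading at this position is also still to be found.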